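The source may hold more compounds than are shown below. What is called first, only, known or untested is meant among the compounds shown, and "the series" means these compounds.

The study measured three cyanoaziridine ureas in a functional assay on OVCAR-3 cells (Homo sapiens) for inhibition; a lower number here means a stronger inhibitor, a higher number a weaker inhibitor. Compound 1 `N#CC1CN1C(=O)Nc1ccc(Cl)c(Cl)c1` gives 5600 nM, compound 2 `CCCCNC(=O)N1CC1C#N` gives 12000 nM, and compound 3 `N#CC1CN1C(=O)Nc1ccc(F)cc1` gives 5900 nM. Compound 3 thus sits among the three numbers with compound 1 nearest, the two values lying within the usual scatter of each other, while compound 2 shows a higher number in this assay, a gap that lies beyond the scatter.

Compound 4 `CCOC(=O)c1ccc(NC(=O)N2CC2C#N)cc1` has not yet been measured. Relative to compound 3 it carries ethoxycarbonyl in place of fluoro on an aromatic carbon. Among the compounds with values here, no step between two measured compounds matches this change, so there is nothing in the measured set from which its size can be read directly. Since compound 3 gives 5900 nM and compound 1 gives 5600 nM in this assay, the two aryl ureas sit close together, and compound 4 is expected to stay in that region, with a step of a 1.2-fold lower number from compound 3 to compound 4 (0.07 log units; within the scatter) that is expected to remain within the scatter. Compound 4 is estimated at 5000 nM, with a range from 1500 nM to 16000 nM.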

Compound 4, half-maximal inhibitory concentration: 7700 nM
For compound 4 the middle estimate is 1.5-fold (0.19 log units) below the measured one; measured number inside the range.
By their numbers in this assay, from the lowest: compounds 1, 3, 4 and 2 (each within the scatter of the next, the first and the last beyond it).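

In this assay, putting ethoxycarbonyl in place of fluoro on an aromatic carbon, para to a group of 8 heavy atoms, gives a 1.3-fold higher number from compound 3 to compound 4 (0.12 log units; within the scatter) on the shared core. Within the data shown here, this is the first pair in the set that differs in one place, and it shows that a single fluorine can give way here to a group of 5 heavy atoms, with 2 hydrogen-bond acceptors and a double bond outside aromatic rings, with no shift that stands clear of the scatter. Nothing measured here accounts for this result.

On these data alone, whether the same holds at this place for an amine, a carboxylic acid or a longer chain remains open. Also open, as far as these compounds go, is how ethoxycarbonyl would fare elsewhere on the aromatic ring.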